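The source may report more compounds than this note shows. Statements on the series, on what has been measured and on what is new or still open speak of the compounds shown alone.

In an ADME assay on MT4 cells (Homo sapiens) for cytotoxicity, read by MTT assay, with a stated time of 96 h (a higher number here means that more compound is tolerated, a lower number that less compound is tolerated), compound 1 `Cc1ccc(/N=N/c2ccc(NCCCN(C)C)cc2)cc1` gives 17000 nM as its reading. Compound 3 `CN(C)CCCN(/N=N/c1c(F)cccc1F)c1ccccc1` gives 23000 nM and so sits within the usual scatter of compound 1, while compound 2 `CN1CCN(/N=N/c2ccccc2)CC1` gives 65000 nM as a higher number beyond that scatter. Compound 4 `CN(C)CCCNc1ccc(/N=N/c2ccccc2)cc1` has not been measured yet. The change from compound 1 to compound 4 is hydrogen in place of methyl on an aromatic carbon in a single place, which means hydrogen in place of methyl on an aromatic carbon, or 4-methylphenyl to phenyl. For the measured compounds named here, no measured pair shows this change, so no step beyond the scatter is expected in this assay, and the estimated step of a 1.2-fold higher number from compound 1 to compound 4 (0.07 log units; within the scatter) stays inside it. Compound 4 is expected at 20000 nM with 9000 nM to 45000 nM as the estimated range.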

Compound 4, half-maximal cytotoxic concentration: 17000 nM
Compound 4: middle estimate off by 1.2-fold (0.07 log units), on the high side; low and high end bracket the measured number.
By their numbers in this assay, from the lowest: compounds 1, 4 and 3 (each within the scatter of the next); then compound 2.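

In this assay the reading shows no change at the digits printed from compound 1 to compound 4 (within the scatter). For the compounds shown here, this is the first measured pair that differs in one place only, and it shows that the methyl on the aromatic carbon can give way to hydrogen, turning 4-methylphenyl into phenyl, with no step beyond the scatter. No measurement here explains this result. On these data alone, whether a methoxy group, a chlorine atom or a carboxylic acid at this same place would also leave the reading in step with compound 1 remains open. A single swap of methyl for hydrogen cannot settle that.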